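This account rests on a few compounds, and the source may have more. Where it says the series, first, only, none or still open, it means among the compounds named here.

Working notes on the series. Compound 1 `Cc1ccc(-c2c3c(nc(C)c2[C@H](OC(C)(C)C)C(=O)O)CCN(c2ccccc2)C3)cc1` and compound 2 `Cc1ccc(-c2c3c(nc(C)c2[C@H](OC(C)(C)C)C(=O)O)CCN(C/C=C/c2ccccc2)C3)cc1` share one core, and compound 3 `Cc1ccc(-c2c3c(nc(C)c2[C@H](OC(C)(C)C)C(=O)O)CCN(C(=O)NCc2ccccc2)C3)cc1` joins them. In an ADME assay on MT2 cells (Homo sapiens) for cytotoxicity, read by XTT assay, with a stated time of 4 days (a lower number here means that less compound is tolerated, a higher number that more compound is tolerated), compound 1 gives > 40000 nM, which is a limit of the assay. In this assay compound 2 gives > 40000 nM, likewise a limit. Going by the values given here, the only measured step is a step that the two limits leave unreadable from compound 1 to compound 2, so compound 2 stands merely at the limit of > 40000 nM in this assay, at which 2 of the 2 values shown sit. Compound 3 differs from compound 2 by benzylcarbamoyl in place of 3-phenylprop-2-en-1-yl on an amine nitrogen in a ring. With no readable step, no shift beyond the scatter is expected. Compound 3 is estimated at 50000 nM (20000 nM to 120000 nM), meaning a step that the limit leaves unreadable from compound 2 to compound 3, most likely reported again as a limit.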

Compound 3, half-maximal cytotoxic concentration: > 40000 nM
Compound 3: only a limit was reported; the forecaster's own chance of this, stated with the estimate: 75%; the middle value does not contradict the limit.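

Compound 1, compound 2 and compound 3 all sit at a limit in this assay, so no step among them can be read: the limit of > 40000 nM in this assay, at which 3 of the 3 values shown sit.

Open remains whether any group on an amine nitrogen in a ring brings cytotoxicity into the readable range.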